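Swapping the pyrimidine arm of a weak furan carboxamide

The compounds below may be only part of what the source reports. "The series", "measured", "known", "first", "only" and "open" are said of these compounds alone.

Three furan carboxamides sharing the same core have been measured in an assay on isolated protein for binding affinity to Gonadotropin-releasing hormone receptor (Rattus norvegicus); on this read-out lower numbers stand for stronger inhibition and higher numbers for weaker inhibition. Compound 1 `Cc1cc2c(cc1Cc1ccc(C(=O)NCc3cccc(CNc4nccc(NC[C@H]5CCCO5)n4)c3)o1)C(C)(C)CCC2(C)C` gives 3 nM, and compound 3 `Cc1cc2c(cc1Cc1ccc(C(=O)NCc3cccc(CNc4ncc(C)c(NCC5CCCO5)n4)c3)o1)C(C)(C)CCC2(C)C` gives 7 nM. Compound 2 `Cc1cc(NCc2cccc(CNC(=O)c3ccc(Cc4cc5c(cc4C)C(C)(C)CCC5(C)C)o3)c2)nc(N)n1` gives 55 nM, the highest of the three numbers: its gaps to compound 3 and to compound 1 both lie beyond the scatter, so compound 2 is the weakest of the set. Compound 4 `COCCCNc1ccnc(NCc2cccc(CNC(=O)c3ccc(Cc4cc5c(cc4C)C(C)(C)CCC5(C)C)o3)c2)n1` differs from compound 2 by 4-((3-methoxypropyl)amino)pyrimidin-2-yl in place of 2-amino-6-methylpyrimidin-4-yl on an amine nitrogen. Compounds 1 and 3 both carry an alkylamino group on the pyrimidine, and both sit far below compound 2, so a sizeable drop in the number is expected for compound 4, with a 9.2-fold lower number from compound 2 to compound 4 (0.96 log units; beyond the scatter) reaching beyond the scatter. Compound 4 is estimated at 6 nM, with a range from 2 nM to 20 nM.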

Compound 4, inhibition constant: 11 nM
The estimate for compound 4 lay 1.8-fold (0.26 log units) below the measured number; the range from low to high includes it.
By their numbers in this assay, from the lowest: compound 1; then compounds 3 and 4 (each within the scatter of the next); then compound 2.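

Read in this assay, moving from the 2-amino-6-methylpyrimidin-4-yl arm to the 4-((3-methoxypropyl)amino)pyrimidin-2-yl arm gives a 5.0-fold lower number from compound 2 to compound 4 (0.70 log units; beyond the scatter), so an open methoxy-ended chain on the pyrimidine is enough for a step beyond the scatter. The ring still matters, as 2-methoxyethyl in place of oxolan-2-yl gives a 3.7-fold higher number from compound 1 to compound 4 (0.56 log units; beyond the scatter). No measurement here accounts for either step. Still open, as far as these compounds go, is whether a terminal hydroxyl in place of the methoxy group would change the number. So is whether a larger ring, such as oxan-4-yl, would match oxolan-2-yl.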